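The source may hold more compounds than are shown below. What is called first, only, known or untested is meant among the compounds shown, and "the series" means these compounds.

Compound 1 `Nc1nn(C(=O)Nc2ccc(Cc3ccccc3)cc2)c2ccccc12` and compound 2 `Nc1nn(C(=O)Nc2ccc(Cc3ccccc3)cc2)c2ccc(Cl)cc12` share one core and differ in a single place. In a functional assay on MOLT-4 cells (Homo sapiens) for antiproliferative activity, read by sulforhodamine B assay, with a stated time of 48 h (on this read-out lower numbers stand for stronger inhibition of growth and higher numbers for weaker inhibition of growth), compound 1 gives 636 nM, while compound 2 gives 2410 nM, the higher of the two numbers and therefore the weaker growth inhibitor of the pair. The gap between them is a 3.8-fold higher number from compound 1 to compound 2 (0.58 log units; beyond the scatter), a modest weakening on adding a chloro to that aromatic carbon. Compound 3 `Nc1ccc2c(c1)c(N)nn2C(=O)Nc1ccc(Cc2ccccc2)cc1` has not yet been measured in this assay. It differs from compound 2 by amino in place of chloro on an aromatic carbon. For the measured compounds named here, only that one measured step touches the same position, and no measured pair carries an amino there, so the direction of the new change is not settled by the data: removing the chloro might bring the number back toward that of compound 1, or the amino might move it elsewhere. Compound 3 is therefore estimated at 1500 nM, with a range from 500 nM to 4500 nM. The step from compound 2 to compound 3 is expected to be a 1.6-fold lower number from compound 2 to compound 3 (0.21 log units; within the scatter).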

Compound 3, concentration for 50% growth inhibition: 4480 nM
The estimate for compound 3 lay 3.0-fold (0.48 log units) below the measured number; the range from low to high includes it.
By their numbers in this assay, from the lowest: compound 1; then compounds 2 and 3 (each within the scatter of the next).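

In this assay, amino in place of chloro on this aromatic carbon gives a 1.9-fold higher number from compound 2 to compound 3 (0.27 log units; within the scatter), so the two groups cannot be told apart at this position. Amino in place of hydrogen gives a 7.0-fold higher number from compound 1 to compound 3 (0.85 log units; beyond the scatter), and chloro in place of hydrogen gave a 3.8-fold higher number from compound 1 to compound 2 (0.58 log units; beyond the scatter), so both substituents tried here, not just chloro, go with weaker growth inhibition than the unsubstituted parent. No measurement shown here accounts for this shared weakening.

Going by these compounds, whether other groups on this carbon, such as fluoro, methoxy or a carboxylic acid, would also weaken growth inhibition, or would match or improve on hydrogen, stays open. So does whether amino would give the same result on the other carbons of this ring.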